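Swapping a Chloro for Pyridin-2-yl: An Expected Step

The compounds below may be only part of what the source reports. "The series", "measured", "known", "first", "only" and "open" are said of these compounds alone.

Of the compounds shown here, three have been measured in an assay on CHO cells for displacement of a labelled ligand from Substance-P receptor (Homo sapiens); on this read-out higher numbers stand for weaker inhibition and lower numbers for stronger inhibition. Compound 1 `COc1ccccc1N1CCN(C(=O)CCc2c(-c3ccc(Cl)cc3)[nH]c3cccc(Cl)c23)CC1` gives 950 nM in this assay, compound 2 `COc1ccccc1N1CCN(C(=O)CCc2c(-c3ccc(Cl)cc3)[nH]c3cc(Cl)ccc23)CC1` gives 4.9 nM, and compound 3 `Cn1c(-c2ccc(Cl)cc2)c(CCC(=O)N2CCC(O)(Cc3ccccc3)CC2)c2cc(Cl)ccc21` gives 0.16 nM. Compound 3 thus stands lowest of the three numbers; its nearest neighbour is compound 2, whose number is higher by a difference beyond the scatter, and compound 1 lies furthest away, with a far higher number, again beyond the scatter.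

Compound 4 `Cn1c(-c2ccc(Cl)cc2)c(CCC(=O)N2CCC(O)(Cc3ccccc3)CC2)c2cc(-c3ccccn3)ccc21` differs from compound 3 in one place: pyridin-2-yl in place of chloro on an aromatic carbon. Going by the values given here, no measured pair shows this kind of change, so the three measured compounds give neither its size nor its direction. The replacement of a single chlorine by a six-membered aromatic ring with one hydrogen-bond acceptor is a larger alteration than any step seen here, and a modest rise in the number, beyond the scatter, is expected, a 3.1-fold higher number from compound 3 to compound 4 (0.49 log units; beyond the scatter). Compound 4 is therefore estimated to give 0.5 nM in this assay, within a range from 0.1 nM to 3 nM.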

Compound 4, half-maximal inhibitory concentration: 1.7 nM
Estimate against measurement, compound 4: 3.4-fold (0.53 log units) below, and the stated range covers the measured number.
By their numbers in this assay, from the lowest: compound 3; then compound 4; then compound 2; then compound 1.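

In this assay, going by these compounds alone, the exchange of chloro for pyridin-2-yl on this aromatic carbon gives an 11-fold higher number from compound 3 to compound 4 (1.03 log units; beyond the scatter) and is the first measured change at this position, showing that the number here responds strongly to the group it carries. The step is large and beyond the scatter, yet compound 4 still gives 1.7 nM in this assay, so the position accepts a six-membered aromatic ring at a clear cost without losing the read-out altogether. Nothing measured here says why the number rises.

The compounds shown leave open whether the rise goes with the ring nitrogen or with the ring as such, which phenyl on the same carbon would separate. They also leave open how far smaller groups, such as fluoro or nitrile, would stay near chloro.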